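Chloro to bromo exchange on the aromatic carbon

A few compounds are considered here, and "the series" means these few. Any claim that something is new, unique, unknown or untested is made for them only; others in the source may bear on it.

Measured so far in an assay on isolated protein for displacement of a labelled ligand from D(4) dopamine receptor (Homo sapiens); on this read-out higher numbers stand for weaker inhibition and lower numbers for stronger inhibition:
compound 1 `O=C(NC1CCN(Cc2ccc(C(F)(F)F)cc2)CC1)c1cccc2ccccc12`: 96 nM
compound 2 `O=C(NC1CCN(Cc2cccc(Cl)c2)CC1)c1ccc2ccccc2c1`: 54 nM

Compound 2 carries the lower of the two numbers, yet compound 1 sits within the usual scatter of it, so the two measurements cannot be told apart; neither compound is called the stronger. Compound 2 also differs from compound 1 in more than one place, so nothing about any single change can be read from that pair.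

Compound 3 `O=C(NC1CCN(Cc2cccc(Br)c2)CC1)c1ccc2ccccc2c1` is the next entry: bromo in place of chloro on an aromatic carbon. Among the compounds with values here, no measured pair in this set separates a chloro from a bromo at such a position, so no step size can be taken from the data. The expectation for this assay is a step of no more than the scatter, in no settled direction. For compound 3 the estimate is 50 nM, with a range from 20 nM to 130 nM, which means an expected step of a 1.1-fold lower number from compound 2 to compound 3 (0.03 log units; within the scatter).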

Compound 3, inhibition constant: 36 nM
Beside the measured number, compound 3's estimate is 1.4-fold (0.14 log units) above it, within the range that was stated.
By their numbers in this assay, from the lowest: compounds 3, 2 and 1 (each within the scatter of the next, the first and the last beyond it).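

Within the data shown here, compounds 2 and 3 form the first pair that differs in one place, so this is the first single change that can be read; steps involving compound 1 cannot be read, as it differs from both in more than one place. In this assay, bromo in place of chloro on the aromatic carbon, meta to a large group, gives a 1.5-fold lower number from compound 2 to compound 3 (0.18 log units; within the scatter), so 3-chlorobenzyl and 3-bromobenzyl cannot be told apart on this read-out.

Open, on these data alone, is whether this position responds at all to a change of another kind: a methoxy, an amine or a carboxylic acid at the same carbon could show that. Also open, as far as these compounds go, is how a plain benzyl, with hydrogen on that carbon, compares with compounds 2 and 3.

Nothing available bears on why the two halogens give numbers within the scatter of each other.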